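The source may report more compounds than this note shows. Statements on the series, on what has been measured and on what is new or still open speak of the compounds shown alone.

In an ADME assay on HepG2 cells (Homo sapiens) for cytotoxicity, in the presence of a further agent that is not named here (a higher number here means a weaker inhibitor, a lower number a stronger inhibitor), compound 2 `Cc1nc(C(=O)NCc2ccccc2)c(O)c(=O)n1C` gives > 100000 nM, which is a limit of the assay and not a number. Compound 2 therefore stands at the limit of > 100000 nM in this assay, at which 2 of the 2 values shown sit. Compound 3 `Cn1c(Cc2ccccc2C(F)(F)F)nc(C(=O)NCc2ccccc2)c(O)c1=O` is compound 2 with a single change: 2-(trifluoromethyl)phenyl in place of hydrogen on a saturated chain carbon bound to an aromatic carbon. Compound 1 `Cn1c(Cc2ccccc2C(F)(F)F)nc(C(=O)NCC2CCCCC2)c(O)c1=O` already carries this same group, with a different group on its amide, and compound 1 gives > 100000 nM, again a limit. On that basis, no change beyond the usual scatter is expected in either direction, and the estimate is a number no higher from compound 2 to compound 3 (the limit leaves the size open). For compound 3 the expected value in this assay is 100000 nM, with an estimated range from 40000 nM to 200000 nM, and the result will most likely be a limit once more.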

Compound 3, half-maximal inhibitory concentration: > 100000 nM
Compound 3: a limit, no number; the forecaster's own chance of this, stated with the estimate: 85%; the middle value sits exactly at the limit.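

In this assay, compound 3 gives a limit and not a number, as do compound 1 and compound 2, and no step among the three can be read: the limit of > 100000 nM in this assay, at which 3 of the 3 values shown sit.

The compounds shown leave open how strongly any of the three acts on these cells, and whether the 2-(trifluoromethyl)phenyl group or the amide group makes any difference to that.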